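A few compounds are considered here, and "the series" means these few. Any claim that something is new, unique, unknown or untested is made for them only; others in the source may bear on it.

Among the measured compounds shown here, in a functional assay on SW-620 cells (Homo sapiens) for antiproliferative activity, read by MTT assay, with a stated time of 24 h (a lower number here means a stronger inhibitor, a higher number a weaker inhibitor), compound 2 `COc1nc(C)c(CCOC(C)=O)c(OC)n1` gives 44000 nM, and this is the only plain number in the set. Compound 1 `COc1nc(Cl)nc(C)c1CCO` reaches only a limit of the assay, > 100000 nM, so no number stands for it. For the measured compounds named here, compound 2 therefore stands alone as the one measured point; the other value is a limit, as stated in the limit of > 100000 nM in this assay, at which 1 of the 2 values shown sits, and no step between two measured compounds can be drawn from it.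

Compound 3 `COc1nc(Cl)nc(C)c1CCOC(C)=O` has not been measured. It differs from compound 2 by one change: chloro in place of methoxy on an aromatic carbon. Compound 1 already carries chloro at this place and sits at the limit, while compound 2, which carries methoxy there, gives a number. On that basis compound 3 is expected to move toward weaker inhibition, and the step from compound 2 to compound 3 is estimated as a 2.0-fold higher number from compound 2 to compound 3 (0.31 log units; beyond the scatter). Compound 3 is thus estimated at 90000 nM, with a range from 30000 nM to 250000 nM.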

Compound 3, half-maximal inhibitory concentration: > 100000 nM
Compound 3: only a limit was reported; the forecaster's own chance of this, stated with the estimate: 50%; at least 1.1-fold (0.04 log units) between middle value and limit.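

In this assay, chloro in place of methoxy on the aromatic carbon between two ring nitrogen atoms gives an at least 2.2-fold higher number from compound 2 to compound 3 (0.35 log units; beyond the scatter). Among the compounds shown here, this is the first readable step in the set, and it is only a minimum, as the value of compound 3 is a limit and not a number. With acetyl on the side-chain oxygen in both compounds, this single change takes the compound from a plain number to the limit, while the step from compound 1 to compound 3 cannot be read, leaving the effect of that acetyl unknown: the limit of > 100000 nM in this assay, at which 2 of the 3 values shown sit.

The compounds shown leave open how an amine or an ethoxy group would read at this position, and whether any group there could do better than compound 2, at 44000 nM. Also open, on these data alone, is how a carboxylic acid would read at the end of the side chain.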